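From thiophen-2-yl to furan-2-yl on the shared core

The source may hold more compounds than are shown below. What is called first, only, known or untested is meant among the compounds shown, and "the series" means these compounds.

compound 1, `CCCSc1nc(Cl)c2c(n1)N(Cc1cccs1)C(C(=O)N1CCN(C)CC1)N2`: 6420 nM
compound 2, `CCCSc1nc(Cl)c2c(n1)N(Cc1ccccc1)C(C(=O)OCC)N2`: 13800 nM

Among the measured compounds shown here, in a functional assay on A549 cells (Homo sapiens) for antiproliferative activity, read by MTT assay, with a stated time of 72 h (a lower number here means a stronger inhibitor, a higher number a weaker inhibitor), compound 1 gives 6420 nM, the lower of the two numbers measured so far. Compound 2 gives 13800 nM, a higher number that lies beyond the usual scatter. Compound 3, `CCCSc1nc(Cl)c2c(n1)N(Cc1ccco1)C(C(=O)N1CCN(C)CC1)N2`, is not yet measured; it differs from compound 1 only in that (furan-2-yl in place of thiophen-2-yl on a saturated chain carbon bound to a nitrogen on an aromatic ring in a ring). For the measured compounds named here, no measured pair shows this change, so the expectation rests on compound 1 alone: the step of a 1.1-fold higher number from compound 1 to compound 3 (0.04 log units; within the scatter) is expected to stay within the scatter, in no set direction. For compound 3 the estimate is 7000 nM, between 3000 nM and 16000 nM.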

Compound 3, half-maximal inhibitory concentration: 13600 nM
Compound 3: middle estimate off by 1.9-fold (0.29 log units), on the low side; the range from low to high includes it.
By their numbers in this assay, from the lowest: compound 1; then compounds 3 and 2 (each within the scatter of the next).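

In this assay, furan-2-yl in place of thiophen-2-yl on a saturated chain carbon bound to a nitrogen on an aromatic ring in a ring gives a 2.1-fold higher number from compound 1 to compound 3 (0.33 log units; beyond the scatter). This first measured pair at this position shows that exchanging the ring sulfur for oxygen, with the heavy-atom count unchanged, moves the number modestly but beyond the scatter. Nothing measured here bears on why the step occurs. The compounds shown leave open how a pyridin-2-yl group or an aminomethyl-substituted thiophene would read at this position.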